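Brine shrimp cytotoxicity: pyridin-3-yl in place of 4-chlorophenyl

The source may report more compounds than this note shows. Statements on the series, on what has been measured and on what is new or still open speak of the compounds shown alone.

Measured so far:
compound 1 `Cc1ccc(S(=O)(=O)NC(=O)Nc2ccccc2C(=O)/C=C/c2ccc(O)cc2)cc1`: 24.3 ug/mL
compound 2 `Cc1ccc(S(=O)(=O)NC(=O)Nc2ccccc2C(=O)/C=C/c2ccc(Cl)cc2)cc1`: 6.92 ug/mL

In an ADME assay on the whole organism for cytotoxicity, with Artemia salina as the target, with a stated time of 24 h (a lower number here means that less compound is needed, a higher number that more compound is needed for the effect), compound 2 stands lowest of the two numbers, and the gap to compound 1 is beyond the scatter. Within the data shown here, the only measured step is a 3.5-fold lower number from compound 1 to compound 2 (0.55 log units; beyond the scatter); it exchanges a substituent on the outer aromatic ring of the shared core and counts as modest.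

Compound 3 `Cc1ccc(S(=O)(=O)NC(=O)Nc2ccccc2C(=O)/C=C/c2cccnc2)cc1` is not yet measured. It differs from compound 2 by pyridin-3-yl in place of 4-chlorophenyl on a double-bonded chain carbon bound to a double-bonded chain carbon. Among the measured compounds shown here, no measured step touches the ring itself; the single step available, a 3.5-fold lower number from compound 1 to compound 2 (0.55 log units; beyond the scatter), concerns only a group on that ring, so it bears on the change loosely at best. It shows that a change at this end of the molecule can move this assay by a modest amount, and that the chloro variant gave the lower number of the two. On that basis a modest rise in the number is expected for compound 3, a 2.2-fold higher number from compound 2 to compound 3 (0.34 log units; beyond the scatter), with a wide range to allow for the untested ring exchange. The estimate for compound 3 in this assay is 15 ug/mL, expected to fall between 5 ug/mL and 45 ug/mL.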

Compound 3, concentration for half-maximal effect: 14.1 ug/mL
Compound 3: the middle estimate sits 1.1-fold (0.03 log units) above what was measured, and the stated range covers the measured number.
By their numbers in this assay, from the lowest: compound 2; then compounds 3 and 1 (each within the scatter of the next).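

In this assay, exchanging the whole ring on a double-bonded chain carbon bound to a double-bonded chain carbon moves the number, with a 2.0-fold higher number from compound 2 to compound 3 (0.31 log units; beyond the scatter) for pyridin-3-yl in place of 4-chlorophenyl. Taken against the 4-hydroxyphenyl compound, the same ring gives a 1.7-fold lower number from compound 1 to compound 3 (0.24 log units; within the scatter), so pyridin-3-yl and 4-hydroxyphenyl cannot be told apart in this assay. Among these compounds, the earlier pair showed only that compound 2 and compound 1 differ; with a third ring in hand, compound 2 stands alone with the lowest number, and its 4-chlorophenyl group is the one exchange among the three that separates from the others. Nothing measured here accounts for the difference between these rings.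

Three compounds cannot show whether the lower number belongs to the chloro group specifically or would also appear with another group on the phenyl ring, such as bromo, methyl or methoxy. Going by these compounds, it is also open whether a pyridine ring carrying a chloro group, or a phenyl ring carrying an amine or a carboxylic acid, would fall with compound 2 or with compound 1 and compound 3.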